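Cyclopropyl in Place of Isobutoxy on a Carbonyl Carbon

This account rests on a few compounds, and the source may have more. Where it says the series, first, only, none or still open, it means among the compounds named here.

Of the compounds shown here, two built on a shared core have so far been measured in an assay on membranes from HeLa cells for displacement of a labelled ligand from adenosine receptor A3 (Homo sapiens), read by scintillation counting, with a stated time of 180 min, tested at 1 uM; on this read-out lower numbers stand for less inhibition and higher numbers for more inhibition at the one concentration tested (going by the name of the read-out). Compound 1 `CC1=C(C(=O)OCC(C)C)C(c2ccoc2)NC(=O)N1` gives 16% in this assay, and compound 2 `CC1=C(C(=O)OCC(C)C)C(c2cccs2)NC(=O)N1` gives 11%. Going by the values given here, the single step connecting them, a number 5 percentage points lower from compound 1 to compound 2 (within the scatter), concerns only the ring attached to the saturated ring carbon. Among the compounds with values here, compound 2 thus carries the lower of the two numbers, with compound 1 as its only neighbour, but the gap between them is within the scatter, so the two cannot be told apart on these data.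

Compound 3 `CC1=C(C(=O)C2CC2)C(c2cccs2)NC(=O)N1` differs from compound 2 elsewhere: cyclopropyl in place of isobutoxy on a carbonyl carbon. Within the data shown here, no measured step touches the carbonyl carbon or anything bound to it, so the one known step offers no guidance on this change, and both measured numbers are modest. Compound 3 is therefore expected to stay near compound 2, with a step of a number 1 percentage points higher from compound 2 to compound 3 (within the scatter) in this assay that is not expected to exceed the scatter. The estimate for compound 3 in this assay is 12%, with a range from 0% to 30%.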

Compound 3, a percentage reported as inhibition, at one concentration (the size of the read-out at that concentration, not a potency): 15%
Beside the measured number, compound 3's estimate is 3 percentage points below it; the range from low to high includes it.
By their numbers in this assay, from the lowest: compounds 2, 3 and 1 (each within the scatter of the next).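

Cyclopropyl in place of isobutoxy, the only change shown on the carbonyl carbon, amounts in this assay to a number 4 percentage points higher from compound 2 to compound 3 (within the scatter). The carbonyl carbon, which the earlier step did not touch, thus takes an exchange of isobutoxy, with 5 heavy atoms, no ring and 1 hydrogen-bond acceptor, for cyclopropyl, with 3 heavy atoms, a three-membered ring and no hydrogen-bond acceptor, without a difference that can be told apart from the scatter, while the thiophen-2-yl group stays in place. No independent evidence bears on why the number stays within the scatter across this exchange.

From the compounds shown here alone, it remains open whether a group of another kind on the carbonyl carbon, such as an amine, a hydroxyl or a longer alkyl chain, would move the number beyond the scatter, or whether any group there can lift the inhibition well above the modest level seen so far at the one concentration tested. Going by these compounds, it is also open whether cyclopropyl would give a similar result with furan-3-yl on the saturated ring carbon in place of thiophen-2-yl.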